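The compounds below may be only part of what the source reports. "The series", "measured", "known", "first", "only" and "open" are said of these compounds alone.

Of the compounds shown here, three of one series have been measured in a functional assay on RPMI8266 cells (Homo sapiens) for inhibition, read by sulforhodamine B assay, with a stated time of 48 h; a higher number here means a weaker inhibitor of growth, a lower number a stronger inhibitor of growth. Compound 1 `COc1cc(C)cc(-c2c(-c3ccnc(-c4ccc(C(C)=O)cc4)c3)cnn2CC#N)c1` gives 2590 nM in this assay, compound 2 `Cc1cc(O)cc(-c2nn(CC#N)cc2-c2ccnc(-c3ccc(Oc4ccccc4)cc3)c2)c1` gives 2250 nM, and compound 3 `COc1cc(C)cc(-c2nn(CC#N)cc2-c2ccnc(-c3ccc(N(C)C)cc3)c2)c1` gives 1360 nM. Compound 3 has the lowest of the three numbers, but its gap to compound 2 and its gap to compound 1 both sit within the scatter of repeated measurements, so none of the three can be set apart from the others on these figures.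

Compound 4 `Cc1cc(O)cc(-c2nn(CC#N)cc2-c2ccnc(-c3ccc(N(C)C)cc3)c2)c1` has not yet been measured. It differs from compound 3 in one place: hydrogen in place of methyl on an oxygen on an aromatic ring. The same exchange, viewed one bond further out, reads methoxy to hydroxy on the 3-methoxy-5-methylphenyl group, which becomes 3-hydroxy-5-methylphenyl. Among the compounds with values here, no measured pair in this set shows this change alone, so its size is unknown here. Compound 2, which carries the hydroxy group alongside a different substituent elsewhere, gives a number close to those of the two methoxy compounds. On that basis compound 4 is expected to land near compound 3, with a step of a 1.3-fold higher number from compound 3 to compound 4 (0.12 log units; within the scatter) that stays within the scatter. The estimated value for compound 4 in this assay is 1800 nM, between 700 nM and 4500 nM.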

Compound 4, concentration for 50% growth inhibition: 3710 nM
Compound 4: the middle estimate sits 2.1-fold (0.31 log units) below what was measured, within the range that was stated.
By their numbers in this assay, from the lowest: compounds 3, 2, 1 and 4 (each within the scatter of the next, the first and the last beyond it).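

In this assay, within the data shown here, this is the first pair in which methoxy to hydroxy on the 3-methoxy-5-methylphenyl group stands alone, and the step is a 2.7-fold higher number from compound 3 to compound 4 (0.44 log units; beyond the scatter) with dimethylamino held constant. Among these compounds, the change therefore weakens growth inhibition modestly but beyond the scatter, which the earlier compounds could not show. With the hydroxy group held constant, dimethylamino in place of phenoxy on an aromatic carbon gives a 1.6-fold higher number from compound 2 to compound 4 (0.22 log units; within the scatter) and so cannot be told apart from no change.

Nothing in the data at hand accounts for the step from methoxy to hydroxy. On these data alone, it remains open whether that step holds with phenoxy in place of dimethylamino, and how an ethoxy group or an amine would read in place of the methoxy.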